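Phenylsulfanyl replaces cyclopropylamino on a shared acylguanidine core

The source may hold more compounds than are shown below. What is called first, only, known or untested is meant among the compounds shown, and "the series" means these compounds.

Measured so far:
compound 1 `NC(N)=NC(=O)c1nc(Cl)c(NCC2CCc3ccccc3C2)nc1N`: 44%
compound 2 `NC(N)=NC(=O)c1nc(Cl)c(NC2CC2)nc1N`: "not determined" (no result reported)
compound 3 `NC(N)=NC(=O)c1nc(Cl)c(NCC2CCCCC2)nc1N`: 28%

In an assay for inhibition of acid-sensing ion channel 3 (Homo sapiens), read by patch clamp, tested at 1 uM (a higher number here means more inhibition at the concentration tested (going by the name of the read-out), a lower number less inhibition), compound 1 gives 44% and compound 3 gives 28%. For compound 2 the entry in this assay reads "not determined" (no result reported), so it stands nowhere on the shown scale and offers no anchor of its own.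

Compound 4 `NC(N)=NC(=O)c1nc(Cl)c(Sc2ccccc2)nc1N` differs from compound 2 in one place: phenylsulfanyl in place of cyclopropylamino on an aromatic carbon. For the measured compounds named here, no step between measured compounds touches this position, so the size of the step in this assay cannot be read from the data; a modest shift either way, not clearly beyond the scatter, is the most that can be said.

Resting on compounds 1 and 3 alone, compound 4 is expected to give about 30% in this assay, within 5% to 60%.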

Compound 4, a percentage reported as inhibition, at one concentration (the size of the read-out at that concentration, not a potency): 11%
For compound 4 the middle estimate is 19 percentage points above the measured one; the measured number falls inside the stated range.
By their numbers in this assay, from the lowest: compound 4; then compound 3; then compound 1.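

In this assay no step can be read between compound 2 and compound 4. The compounds shown leave open how phenylsulfanyl compares with cyclopropylamino at this position. No supporting evidence bears on this result.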